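Swapping the Amine Tail on a Shared Core

This account rests on a few compounds, and the source may have more. Where it says the series, first, only, none or still open, it means among the compounds named here.

Measured so far in an ADME assay on cells (Homo sapiens) for cytotoxicity, read by polymerase chain reaction, with a stated time of 3 days; a lower number here means that less compound is tolerated, a higher number that more compound is tolerated:
Compound 1, `Cc1nc(NCC(C)C)nc(N[C@@H]2C[C@H](CO)[C@@H](O)[C@H]2O)c1-c1nc2ccccc2s1`, gives 10000 nM.
Compound 2, `Cc1nc(N(C)C)nc(N[C@@H]2C[C@H](CO)[C@@H](O)[C@H]2O)c1-c1nc2ccccc2s1`, gives 18000 nM.

Among the measured compounds shown here, compound 2 carries the highest of the two numbers, yet the only step that separates it from compound 1, a 1.8-fold higher number from compound 1 to compound 2 (0.26 log units; within the scatter), lies within the usual scatter of this assay, so the two compounds cannot be put in order on this evidence.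

Compound 3, `CCOCCNc1nc(C)c(-c2nc3ccccc3s2)c(N[C@@H]2C[C@H](CO)[C@@H](O)[C@H]2O)n1`, is the next point on the same core. It differs from compound 2 in one place: (2-ethoxyethyl)amino in place of dimethylamino on an aromatic carbon. For the measured compounds named here, the single measured step that bears on this change is a 1.8-fold higher number from compound 1 to compound 2 (0.26 log units; within the scatter), where one amine tail replaced another at the same aromatic carbon and the number moved only within the scatter. The tail entering in compound 3 again brings one hydrogen-bond donor, as the tail of compound 1 does, and adds an ether oxygen to the chain. Going by the values given here, no other step in the set speaks to this change.

The expected step is therefore a 1.5-fold lower number from compound 2 to compound 3 (0.18 log units; within the scatter), essentially none beyond the scatter. Compound 3 is estimated at 12000 nM, with a likely range from 5000 nM to 30000 nM.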

Compound 3, half-maximal cytotoxic concentration: 18000 nM
Compound 3: the middle estimate sits 1.5-fold (0.18 log units) below what was measured; measured number inside the range.
By their numbers in this assay, from the lowest: compounds 1, 2 and 3 (each within the scatter of the next).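

At this position, on an aromatic carbon between two ring nitrogen atoms, a much larger tail is now tested: in this assay, (2-ethoxyethyl)amino, with 6 heavy atoms, an ether oxygen and 1 hydrogen-bond donor, replaces dimethylamino, with 3 heavy atoms and 0 hydrogen-bond donors, and gives no change at the digits printed from compound 2 to compound 3 (within the scatter). The comparison with the isobutylamino tail, where ethoxymethyl stands in place of isopropyl on a saturated chain carbon bound to a nitrogen on an aromatic ring, gives a 1.8-fold higher number from compound 1 to compound 3 (0.26 log units; within the scatter), so this read-out does not separate the branched carbon tail from the ether tail. All three compounds now lie within the scatter of one another, which means that these three tails cannot be put in order, and nothing measured here offers an explanation for this flat result.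

The compounds shown leave open whether a different kind of tail at this position, such as a chain ending in a carboxylic acid or a primary amine, or a much longer alkyl chain, would move the number beyond the scatter. They also leave open whether these three tails would stay this close in any measurement other than cytotoxicity.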